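Propylsulfonyl to methylsulfonyl on the fluorinated aryl alkyne

The source may report more compounds than this note shows. Statements on the series, on what has been measured and on what is new or still open speak of the compounds shown alone.

The series shares a chloro-substituted aryloxyacetic acid core linked through an alkyne to a sulfonyl-bearing aryl ring. In a functional assay on cells for antagonist activity at prostaglandin D2 receptor 2 (Homo sapiens), read by flow cytometry, with a stated time of 10 min (a higher number here means a weaker inhibitor, a lower number a stronger inhibitor), compound 1 `CCCS(=O)(=O)c1cccc(C#Cc2cc(Cl)ccc2OCC(=O)O)c1` gives 750 nM. Within the data shown here, compound 2 `CCCS(=O)(=O)c1ccc(F)c(C#Cc2cc(Cl)ccc2OCC(=O)O)c1` gives 23 nM, and the step of a 33-fold lower number from compound 1 to compound 2 (1.51 log units; beyond the scatter) is the only single-point change measured so far. Compound 3 `Cc1ccc(S(=O)(=O)N(C)C)cc1C#Cc1cc(Cl)ccc1OCC(=O)O` gives 77 nM in this assay.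

Compound 2 therefore holds the lowest of the three measured values; compound 3 stands nearest, with a higher number beyond the scatter, and compound 1 stands furthest, higher still.

Compound 4 `CS(=O)(=O)c1ccc(F)c(C#Cc2cc(Cl)ccc2OCC(=O)O)c1` differs from compound 2 by hydrogen in place of ethyl on a saturated chain carbon bound to a sulfonyl sulfur; the same difference, cut one bond further out, reads propyl to methyl, propylsulfonyl to methylsulfonyl. Among the measured compounds shown here, no measured step touches this part of the molecule: the single step known changes a ring substituent, not the sulfonyl chain, and compound 3 differs from compound 2 in more than one place, so its value gives no clean reading on chain length alone. With nothing in the data pointing either way, the expected step in this assay from compound 2 to compound 4 is a 1.7-fold higher number from compound 2 to compound 4 (0.24 log units; within the scatter), which is estimated to be small. Compound 4 is accordingly expected to give about 40 nM, within an estimated range of 12 nM to 150 nM.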

Compound 4, half-maximal inhibitory concentration: 95 nM
Compound 4: the middle estimate sits 2.4-fold (0.38 log units) below what was measured; low and high end bracket the measured number.
By their numbers in this assay, from the lowest: compound 2; then compounds 3 and 4 (each within the scatter of the next); then compound 1.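

In this assay, among these compounds, the change from propylsulfonyl to methylsulfonyl gives a 4.1-fold higher number from compound 2 to compound 4 (0.62 log units; beyond the scatter), so the saturated chain on the sulfonyl sulfur is a place where the read-out responds, which no earlier step could show. Among the compounds shown here, this step is classed as modest, whereas the only other single-place step, a 33-fold lower number from compound 1 to compound 2 (1.51 log units; beyond the scatter), is classed as large, so on the compounds at hand the chain change carries less weight than the ring fluoro change, although it still lies beyond the scatter. Within this pair the propyl chain goes with the lower number, and nothing measured bears on why the shorter chain gives the higher number.

Going by these compounds, with only propyl and methyl compared on this scaffold, no trend along the chain can be stated, and it remains open whether an ethyl, a butyl or a branched isopropyl group on the sulfonyl sulfur would fall on either side of compound 2. Also open, on these data alone, is whether a cyclopropyl group or an amine at the same sulfonyl sulfur would hold the number of compound 2, and whether the chain step keeps its size when the ring fluoro is replaced by hydrogen.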